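A few compounds are considered here, and "the series" means these few. Any claim that something is new, unique, unknown or untested is made for them only; others in the source may bear on it.

Compound 3 `O=C(O)c1ccc(-c2cnc(C(=O)CCCCCCc3ccccc3)o2)cc1` sits second highest of the three numbers in hand: in an assay (Rattus norvegicus) for inhibition of Fatty-acid amide hydrolase 1 (Homo sapiens) (a lower number here means a stronger inhibitor, a higher number a weaker inhibitor), compound 3 gives 60 nM, close to compound 1 `O=C(CCCCCCc1ccccc1)c1ncc(-c2ccccc2F)o1`, which in this assay gives 110 nM, and further from compound 2 `N#Cc1cccc(-c2cnc(C(=O)CCCCCCc3ccccc3)o2)c1`, which in this assay gives 15 nM. The steps between them are modest: a 7.3-fold lower number from compound 1 to compound 2 (0.87 log units; beyond the scatter), a 1.8-fold lower number from compound 1 to compound 3 (0.26 log units; within the scatter) and a 4.0-fold higher number from compound 2 to compound 3 (0.60 log units; beyond the scatter).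

Compound 4 `O=C(CCCCCCc1ccccc1)c1ncc(-c2ccc(F)cc2)o1` differs from compound 3 by a single exchange, (fluoro in place of carboxy on an aromatic carbon). Among the measured compounds shown here, no measured step swaps one small group for another on this ring; the nearest guide is compound 1, whose 2-fluorophenyl is close in this assay to the 4-carboxyphenyl of compound 3, and none of the three aryl variants moves the number far. Compound 4 is therefore expected to show a step of about a 1.2-fold higher number from compound 3 to compound 4 (0.07 log units; within the scatter), which lies within the scatter. The estimate for compound 4 in this assay is 70 nM, with a range from 25 nM to 200 nM.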

Compound 4, inhibition constant: 62 nM
For compound 4 the middle estimate is 1.1-fold (0.05 log units) above the measured one; the measured number falls inside the stated range.
By their numbers in this assay, from the lowest: compound 2; then compounds 3, 4 and 1 (each within the scatter of the next).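

In this assay, carboxy and fluoro on the aromatic carbon para to a large group cannot be told apart, with a 1.0-fold higher number from compound 3 to compound 4 (0.01 log units; within the scatter), even though carboxy carries a hydrogen-bond donor and fluoro carries none. Among the compounds shown here, the two fluorophenyl variants also stay together, with a 1.8-fold lower number from compound 1 to compound 4 (0.25 log units; within the scatter), while a 4.1-fold higher number from compound 2 to compound 4 (0.62 log units; beyond the scatter) shows that 3-cyanophenyl remains the one aryl group here set apart from the others. No measurement among the data bears on why these groups read as they do.

The compounds shown leave open whether the nitrile itself or its place on the ring sets compound 2 apart, a question that a 4-cyanophenyl or a 3-fluorophenyl group would help to separate. Going by these compounds, how an amine or a methoxy group would read at this position also remains open.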